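Carboxypropyl Chain Replaces Tetrazole Branch in Compound 4

The source may report more compounds than this note shows. Statements on the series, on what has been measured and on what is new or still open speak of the compounds shown alone.

Going by the values given here, compound 3 `CCCc1c(COc2ccc(C(=O)C(C)(C)Cc3nnn[nH]3)cc2)ccc(C(C)=O)c1O` gives 6.93 in a functional assay on ileum (Cavia porcellus) with cysteinyl leukotriene receptor (Homo sapiens) as the target (a lower number here means a less potent compound, a higher number a more potent compound, by a factor of ten per unit of this negative logarithm), the second highest of the three numbers so far; compound 1 `CCCc1c(COc2ccc(C(=O)CCC(=O)O)cc2)ccc(C(C)=O)c1O` gives 6.75, and compound 2 `CCCc1c(COc2ccc(C(=O)C(C)Cc3nnn[nH]3)cc2)ccc(C(C)=O)c1O` gives 7.18. The steps of a number 0.18 log units higher from compound 1 to compound 3 (within the scatter) and a number 0.25 log units lower from compound 2 to compound 3 (within the scatter) both lie within the scatter, while a number 0.43 log units higher from compound 1 to compound 2 (beyond the scatter) is modest. Compound 4 `CCCc1c(COc2ccc(C(=O)CCCC(=O)O)cc2)ccc(C(C)=O)c1O` differs from compound 3 by 3-carboxypropyl in place of 1-((1H-tetrazol-5-yl)methyl)-1-methylethyl on a carbonyl carbon. Among the compounds with values here, this change is nearly the reverse of a number 0.18 log units higher from compound 1 to compound 3 (within the scatter), except that the acid arrives as 3-carboxypropyl rather than the 2-carboxyethyl of compound 1, and no measured step covers that lengthening. Compound 4 is therefore expected to land close to where compound 1 stands. The expected step is a number 0.23 log units lower from compound 3 to compound 4 (within the scatter). Compound 4 is estimated at 6.7, within 6.2 to 7.2.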

Compound 4, negative logarithm of the antagonist equilibrium constant: 6.81
Beside the measured number, compound 4's estimate is 0.11 log units below it, within the range that was stated.
By their numbers in this assay, from the lowest: compounds 1, 4, 3 and 2 (each within the scatter of the next, the first and the last beyond it).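

Exchanging the branched tetrazole chain for 3-carboxypropyl on a carbonyl carbon gives a number 0.12 log units lower from compound 3 to compound 4 (within the scatter) and lengthening the acid chain gives a number 0.06 log units higher from compound 1 to compound 4 (within the scatter), so neither exchange moves the number past the scatter. The exchange that does pass it starts from 1-((1H-tetrazol-5-yl)methyl)ethyl, with a number 0.37 log units lower from compound 2 to compound 4 (beyond the scatter) as a modest step. Nothing available accounts for these steps. Still open, going by these compounds, is whether a methyl on the 3-carboxypropyl chain, or a longer carboxylic acid chain, would hold the number in this range, and how an amine in place of the acid would compare.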